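The source may hold more compounds than are shown below. What is called first, only, known or untested is meant among the compounds shown, and "the series" means these compounds.

Among the measured compounds shown here, in an ADME assay on HEL cells (Homo sapiens) for cytotoxicity, with a stated time of 3 days (on this read-out lower numbers stand for higher toxicity in this test and higher numbers for lower toxicity in this test), compound 1, `Cc1cc(-c2cccc(O)c2)c2ncc(CSCCc3ccccc3)n2c1`, gives 11.4 ug/mL, the only exact number available so far. Compound 2, `COc1cccc(-c2cc(C)cn3c(CSCCc4ccccc4)cnc23)c1`, is reported only as a limit, > 50 ug/mL. Compound 3, `Cc1cc(-c2cccs2)c2ncc(CSCCc3ccccc3)n2c1`, carries thiophen-2-yl in place of 3-hydroxyphenyl on an aromatic carbon of the shared core: thiophen-2-yl in place of 3-hydroxyphenyl on an aromatic carbon. For the measured compounds named here, one measured step bears on this change, namely methyl in place of hydrogen on an oxygen on an aromatic ring, which gives an at least 4.3-fold higher number from compound 1 to compound 2 (0.64 log units; beyond the scatter), a change beyond the scatter. Compound 3 also loses that hydrogen, so a move in the same direction is expected. Going by the values given here, no measured step covers the exchange of the whole ring, so the expected size remains uncertain and may be smaller. The expected change is a 2.5-fold higher number from compound 1 to compound 3 (0.39 log units; beyond the scatter). Compound 3 is expected at 28 ug/mL, with an estimated range from 12 ug/mL to 60 ug/mL.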

Compound 3, half-maximal cytotoxic concentration: > 50 ug/mL
Compound 3 was reported as a limit; the forecaster's own chance of this, stated with the estimate: 35%; middle value at least 1.7-fold (0.25 log units) from the limit.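

In this assay thiophen-2-yl in place of 3-hydroxyphenyl on this aromatic carbon gives an at least 4.3-fold higher number from compound 1 to compound 3 (0.64 log units; beyond the scatter), so the higher number does not depend on keeping a phenyl ring here, whereas the earlier pair changed only the group on the oxygen. Compound 3 stands at a limit of the assay, and the step from compound 2 to compound 3 cannot be read because both compounds sit at that limit: the limit of > 50 ug/mL in this assay, at which 2 of the 3 values shown sit. Of the three compounds, only compound 1 carries the hydroxyl hydrogen, and only compound 1 has an exact number.

Going by these compounds, whether an amine or a carboxylic acid on the phenyl ring in place of the hydroxyl would also give a lower number remains open. On these data alone, how far compound 2 and compound 3 lie past the limit also remains open.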